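Aryl swap on the shared core: compound 1 to compound 4

A few compounds are considered here, and "the series" means these few. Any claim that something is new, unique, unknown or untested is made for them only; others in the source may bear on it.

Among the measured compounds shown here, compound 1 `Cc1cccc(Nc2nccc(-c3cc(C)oc3C)n2)c1` gives 28500 nM in a functional assay for inhibition, with Homo sapiens as the target (a higher number here means a weaker inhibitor, a lower number a stronger inhibitor), and stands at the highest of the three numbers measured so far. Compound 2 `CCOC(=O)c1cccc(Nc2nccc(-c3cccnc3)n2)c1` gives 10500 nM in this assay, and compound 3 `CN(C)c1ccc(Nc2nccc(-c3ccco3)n2)cc1` gives 1900 nM. Compound 1 thus lies nearest to compound 2 and furthest from compound 3, and both gaps are beyond the usual scatter. For the measured compounds named here, the three measured compounds differ from one another in more than one place, so no single step between them can be read off.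

Compound 4 `Cc1cccc(Nc2nccc(-c3ccccn3)n2)c1` is not yet measured. Its change from compound 1 is pyridin-2-yl in place of 2,5-dimethylfuran-3-yl on an aromatic carbon. Going by the values given here, no measured pair shows this change on its own, so the size of the step is open. The step from compound 1 to compound 4 is expected to be a 2.0-fold lower number from compound 1 to compound 4 (0.31 log units; beyond the scatter), a move toward a lower number of modest size, not far beyond the scatter. Compound 4 is therefore expected to give 14000 nM in this assay, with a range from 4000 nM to 50000 nM.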

Compound 4, half-maximal inhibitory concentration: 700 nM
Beside the measured number, compound 4's estimate is 20-fold (1.30 log units) above it; measured number outside the range, below it.
By their numbers in this assay, from the lowest: compound 4; then compound 3; then compound 2; then compound 1.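

Among the compounds shown here, the first step that differs in one place sits at this aromatic carbon of the shared core: pyridin-2-yl in place of 2,5-dimethylfuran-3-yl is a 41-fold lower number from compound 1 to compound 4 (1.61 log units; beyond the scatter) in this assay, so the number responds strongly to the group here. The two groups have the same counts of hydrogen-bond donors and acceptors and no net charge, so those counts do not track the step, while ring size, hetero atom and the two methyl groups all change at once. Nothing at hand accounts for the size of this step.

From the compounds shown here alone, whether the step belongs to the ring nitrogen, the six-membered ring or the loss of the methyl groups stays open, and compound 2 and compound 3 differ from compound 4 in more than one place, so they cannot settle it. A phenyl or pyridin-4-yl group at this position on the same core would separate these changes.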